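Octadecylamide threonine series: acyl substitution at the amine

The source may report more compounds than this note shows. Statements on the series, on what has been measured and on what is new or still open speak of the compounds shown alone.

Measured so far:
compound 1, `CCCCCCCCCCCCCCCCCCNC(=O)[C@@H](N)[C@@H](C)O`, 21400 nM in a functional assay on SW-620 cells (Homo sapiens) for cytotoxicity, read by MTT assay, with a stated time of 48 h; a lower number here means a stronger inhibitor, a higher number a weaker inhibitor
compound 2, `CCCCCCCCCCCCCCCCCCNC(=O)[C@@H](NC(=O)/C=C/c1ccccc1)[C@@H](C)O`, 200000 nM in this assay

Compound 2 stands at the highest number of the two measured; compound 1 sits below it by the step of a 9.3-fold higher number from compound 1 to compound 2 (0.97 log units; beyond the scatter), which came from putting (2-phenylethenyl)carbonyl in place of hydrogen on the amine nitrogen.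

Compound 3, `C/C=C/C=C/C(=O)N[C@H](C(=O)NCCCCCCCCCCCCCCCCCC)[C@@H](C)O`, is not yet measured. It differs from compound 2 by prop-1-en-1-yl in place of phenyl on a double-bonded chain carbon bound to a double-bonded chain carbon. Going by the values given here, no measured step exchanges one acyl group for another; the only step known, a 9.3-fold higher number from compound 1 to compound 2 (0.97 log units; beyond the scatter), concerns the presence of the acyl group rather than its shape, so it bears on the new compound only loosely. With the ((penta-1,3-dien-1-yl)carbonyl)amino group the compound keeps an acyl group on the amine nitrogen, which in compound 2 went with the weaker number.

The working expectation for compound 3 in this assay is therefore 120000 nM, between 35000 nM and 300000 nM. Among the compounds with values here, this expected step, a 1.7-fold lower number from compound 2 to compound 3 (0.22 log units; within the scatter), is set near neutral, with the wide range reflecting that no measured pair informs the phenyl to prop-1-en-1-yl exchange directly.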

Compound 3, half-maximal inhibitory concentration: 200000 nM
The estimate for compound 3 lay 1.7-fold (0.22 log units) below the measured number; the range from low to high includes it.
By their numbers in this assay, from the lowest: compound 1; then compounds 2 and 3 (each within the scatter of the next).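

In this assay, going by these compounds alone, prop-1-en-1-yl in place of phenyl on a double-bonded chain carbon bound to a double-bonded chain carbon gives the first acyl-for-acyl comparison (no change at the digits printed from compound 2 to compound 3 (within the scatter)), so the six-membered aromatic ring of carbon only can be exchanged for this open chain with no difference beyond the scatter. The free amine now also has a second acylated comparison, with (penta-1,3-dien-1-yl)carbonyl in place of hydrogen on the amine nitrogen (a 9.3-fold higher number from compound 1 to compound 3 (0.97 log units; beyond the scatter)) matching the earlier (2-phenylethenyl)carbonyl step (a 9.3-fold higher number from compound 1 to compound 2 (0.97 log units; beyond the scatter)), so the link between acylation and the weaker number holds for both acylated compounds shown, and none goes against it. No supporting data are available to account for either the shared step or the absence of a difference between the two acyl groups.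

The compounds shown leave open whether this link extends to an acyl group without a carbon-carbon double bond, such as acetyl, or to one carrying a carboxylic acid or an amine. They also leave open whether any acyl group on the amine nitrogen would return the number toward that of compound 1 (21400 nM).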